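This account rests on a few compounds, and the source may have more. Where it says the series, first, only, none or still open, it means among the compounds named here.

Two compounds of the series carry numbers in an assay (Equus caballus) for inhibition of Thromboxane-A synthase (Homo sapiens), using microsomes; on this read-out lower numbers stand for stronger inhibition and higher numbers for weaker inhibition. Within the data shown here, compound 1 `O=C(O)C(CCC/C=C(\c1ccccc1)c1cccnc1)C1(O)CCCC1` gives 65 nM in this assay, the higher of the two numbers so far, though the gap to compound 2 `O=C(O)CCCC/C=C(/c1cccnc1)c1cccs1`, which gives 54 nM, lies within the scatter, so the two cannot be set in order on this read-out. Compound 3 `C=CCC(CCC/C=C(\c1ccccc1)c1cccnc1)C(=O)O` has not yet been measured in this assay. Against compound 1 it carries allyl in place of 1-hydroxycyclopentyl on a saturated chain carbon bound to a carbonyl carbon and a saturated chain carbon. Among the measured compounds shown here, no step between measured compounds shows what this change does, and compound 2, whose chain carries neither group, offers only its own number as a reference. The change is expected to move the number by no more than the scatter, in either direction, with the wider range allowing a moderate shift. Compound 3 is expected to give 60 nM in this assay, with a range from 20 nM to 200 nM, so that the step of a 1.1-fold lower number from compound 1 to compound 3 (0.03 log units; within the scatter) is estimated as essentially flat.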

Compound 3, half-maximal inhibitory concentration: 50 nM
For compound 3 the middle estimate is 1.2-fold (0.08 log units) above the measured one; the range from low to high includes it.
By their numbers in this assay, from the lowest: compounds 3, 2 and 1 (each within the scatter of the next).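

In this assay, allyl in place of 1-hydroxycyclopentyl on a saturated chain carbon bound to a carbonyl carbon and a saturated chain carbon gives a 1.3-fold lower number from compound 1 to compound 3 (0.11 log units; within the scatter), the first step read at this position. The number thus holds when the five-membered ring and the hydrogen-bond donor and acceptor of the leaving group are gone, and neither is required at this position for a value of this size. Nothing on hand accounts for this flat step.

Still open, on these data alone, is whether this position accepts other kinds of group, such as an amine, a second carboxylic acid or a longer alkyl chain, without a step beyond the scatter. Also open, as far as these compounds go, is whether the same exchange stays flat on the core of compound 2.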